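Cytotoxicity notes: urea to semicarbazide change

The source may report more compounds than this note shows. Statements on the series, on what has been measured and on what is new or still open speak of the compounds shown alone.

Compound 3 `COc1cc(NC(C)CCCNC(=O)Nc2cccc(Cl)c2)c2ncccc2c1` gives 10 ug/mL in an ADME assay on L6 cells (Rattus norvegicus) for cytotoxicity, read by resazurin assay, with a stated time of 70 h (on this read-out higher numbers stand for weaker inhibition and lower numbers for stronger inhibition), and stands highest of the three numbers measured, though only within the scatter of its neighbours: compound 2 `COc1cc(NC(C)CCCNC(=O)Nc2ccc(F)cc2)c2ncccc2c1` gives 9.3 ug/mL, compound 1 `COc1cc(NC(C)CCCNC(=O)/C=C/c2ccccc2)c2ncccc2c1` gives 7.2 ug/mL, and the steps of a 1.3-fold higher number from compound 1 to compound 2 (0.11 log units; within the scatter), a 1.4-fold higher number from compound 1 to compound 3 (0.14 log units; within the scatter) and a 1.1-fold higher number from compound 2 to compound 3 (0.03 log units; within the scatter) all lie within the scatter. Compound 4 `COc1cc(NC(C)CCCNC(=O)NNC(=O)Nc2ccc(Cl)cc2)c2ncccc2c1` carries ((4-chlorophenyl)carbamoyl)amino in place of 3-chlorophenyl on an amide-type nitrogen. Among the measured compounds shown here, none of the measured steps touches the amide-type nitrogen in this way; they only exchange aryl or alkenyl groups on the carbonyl side, and all stayed within the scatter, so no step beyond the scatter is expected in this assay here either. Compound 4 is therefore estimated at 10 ug/mL, within a range of 4 ug/mL to 25 ug/mL, the expected step being no change at the digits printed from compound 3 to compound 4 (within the scatter).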

Compound 4, half-maximal inhibitory concentration: 43.3 ug/mL
Compound 4: middle estimate off by 4.3-fold (0.64 log units), on the low side, and the stated range ends below it.
By their numbers in this assay, from the lowest: compounds 1, 2 and 3 (each within the scatter of the next); then compound 4.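

In this assay, among the compounds shown here, ((4-chlorophenyl)carbamoyl)amino on the amide-type nitrogen gives a 4.3-fold higher number from compound 3 to compound 4 (0.64 log units; beyond the scatter) and a 4.7-fold higher number from compound 2 to compound 4 (0.67 log units; beyond the scatter), the first steps beyond the scatter, both towards weaker inhibition. Exchanging 4-fluorophenyl for 3-chlorophenyl at this nitrogen stayed within the scatter, so this position does respond, but to the larger replacement. Nothing available bears on the cause of these steps.

Compound 4 differs from compound 3 in both the added carbamoylamino unit and the chlorine placement, and the compounds shown do not separate the two. From the compounds shown here alone, how an amine or a longer alkyl chain on this nitrogen would read remains open.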